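The compounds below may be only part of what the source reports. "The series", "measured", "known", "first", "only" and "open" are said of these compounds alone.

In a physicochemical assay for lipophilicity, read by HPLC, in phosphate buffer, measured as octanol-water partition, at pH 7.4, tested at 100 uM (a lower number here means a more polar compound, a higher number a more lipophilic compound), compound 1 `O=C(O)COc1ccc(NCc2cccc(-c3ccccc3)c2)cc1F` gives 2.25 while compound 2 `O=C(O)COc1ccc(NCc2cccc(-c3ccccc3Cl)c2)cc1F` gives 2.71 and so holds the higher of the two numbers. The move to compound 3 `Cc1ccccc1-c1cccc(CNc2ccc(OCC(=O)O)c(F)c2)c1` leaves the shared core untouched and puts methyl in place of chloro on an aromatic carbon, ortho to a large group (methyl in place of chloro on an aromatic carbon). Within the data shown here, the one measured step that bears on this is a number 0.46 log units higher from compound 1 to compound 2 (beyond the scatter) where chloro takes the place of hydrogen. Among the measured compounds shown here, no measured pair exchanges chloro for methyl directly, so that step serves only as a loose guide. Set against a number 0.46 log units higher from compound 1 to compound 2 (beyond the scatter) as a yardstick, a much smaller and slightly downward change is expected, with no shift beyond the scatter. The expected step is a number 0.11 log units lower from compound 2 to compound 3 (within the scatter) in this estimate. In this assay compound 3 is estimated at 2.6 with 2.3 to 2.85 as the expected range.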

Compound 3, distribution coefficient: 2.41
Compound 3: the middle estimate sits 0.19 log units above what was measured; low and high end bracket the measured number.
By their numbers in this assay, from the lowest: compounds 1, 3 and 2 (each within the scatter of the next, the first and the last beyond it).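

In this assay, the exchange of 2-chlorophenyl for 2-methylphenyl gives a number 0.30 log units lower from compound 2 to compound 3 (within the scatter), while methyl in place of hydrogen at the same aromatic carbon gives a number 0.16 log units higher from compound 1 to compound 3 (within the scatter). Compound 3 therefore lies within the scatter of both compound 1 and compound 2, even though those two lie beyond the scatter of each other, so at this position methyl, unlike chloro, is not separated from hydrogen by this read-out. Nothing at hand offers a reason why these two groups, each of one heavy atom, part in this way. On these data alone, how a methoxy group, a hydroxyl or an amine on this same aromatic carbon would read in this assay stays open. As far as these compounds go, it is also open whether chloro and methyl would stand the same way with a different group in place of the fluoro on the shared core.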